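Swapping Methoxy for Chloro in a Weakly Active Series

The source may hold more compounds than are shown below. What is called first, only, known or untested is meant among the compounds shown, and "the series" means these compounds.

Of the compounds shown here, three have been tested in an assay on isolated protein for inhibition of malate dehydrogenase, mitochondrial (Sus scrofa), with stated times of 45 min and 30 min; on this read-out lower numbers stand for stronger inhibition and higher numbers for weaker inhibition: compound 1 `O=S(=O)(Nc1ccc2oc(-c3ccccc3)nc2c1)c1ccccc1C(F)(F)F`, compound 2 `COc1cccc(S(=O)(=O)Nc2ccc3oc(-c4ccccc4)nc3c2)c1` and compound 3 `O=S(=O)(Nc1ccc(-c2nc3ccccc3o2)cc1)c1ccccc1Cl`. In this assay compound 1 gives > 63000 nM, which is a limit of the assay and not a number. Compound 2 gives > 63000 nM, likewise a limit. Compound 3 gives > 63000 nM, also a limit. Compound 2 therefore stands where every value shown stands, at the limit of > 63000 nM in this assay, at which 3 of the 3 values shown sit. Compound 4 `O=S(=O)(Nc1ccc2oc(-c3ccccc3)nc2c1)c1cccc(Cl)c1` has not yet been measured in this assay. It differs from compound 2 in one place: chloro in place of methoxy on an aromatic carbon. The change leaves methoxy and brings in chloro, on an aromatic carbon of a six-membered aromatic ring of carbon only, meta to a large group. Among the compounds with values here, no step between measured compounds exists to show how such a change moves the read-out. With every measured value sitting at the limit, the step is expected to be none beyond the scatter: a step that the limit leaves unreadable from compound 2 to compound 4. Compound 4 is expected to give 100000 nM, between 40000 nM and 300000 nM, most likely reported again only as a limit.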

Compound 4, half-maximal inhibitory concentration: > 63000 nM
Compound 4: a limit, no number (the forecaster's own chance of this, stated with the estimate: 85%); the middle value is on the limit's open side.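

Compound 4 gives > 63000 nM, a limit and not a number. Compound 2 also sits at a limit, so no step can be read between compound 2 and compound 4. The compounds shown leave open how strongly any of them inhibits the enzyme, and whether swapping methoxy for chloro changes that at all.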